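The source may hold more compounds than are shown below. What is called first, only, known or untested is meant among the compounds shown, and "the series" means these compounds.

Compound 2, `CCCCCNC(=O)c1n[nH]cc1NC(=O)c1c(OC)cccc1OC`, is one of two compounds that have been measured in an ADME assay on MRC5 cells (Homo sapiens) for inhibition, with a stated time of 72 h; a lower number here means that less compound is needed, a higher number that more compound is needed for the effect. In this assay compound 2 gives > 50000 nM, which is a limit of the assay rather than a number. Compound 1, `COc1cccc(OC)c1C(=O)Nc1c[nH]nc1C(=O)Nc1ccncc1`, is the other measured compound. In this assay compound 1 gives > 50000 nM, again a limit. For the measured compounds named here, the only measured step, a step that the two limits leave unreadable from compound 1 to compound 2, cannot be read in size, because of the limit of > 50000 nM in this assay, at which 2 of the 2 values shown sit. Compound 3, `COc1cccc(OC)c1C(=O)Nc1c[nH]nc1C(=O)Nc1ccccc1`, is not yet measured and differs from compound 2 by phenyl in place of pentyl on an amide-type nitrogen. Going by the values given here, no measured step bears on this change with a readable size, so nothing in the data points to a gain or a loss in this assay beyond the scatter. Compound 3 is therefore expected to give 80000 nM, within a range from 20000 nM to 300000 nM, and most likely to be reported again only as a limit. The step that the limit leaves unreadable from compound 2 to compound 3 is accordingly expected to stay within the scatter.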

Compound 3, half-maximal effective concentration: > 50000 nM
Compound 3 was reported as a limit (the forecaster's own chance of this, stated with the estimate: 85%); the middle value is on the limit's open side.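

For the compounds shown here, no step among compound 1, compound 2 and compound 3 can be read in size in this assay, because all three sit at the same limit: the limit of > 50000 nM in this assay, at which 3 of the 3 values shown sit.

The compounds shown leave open whether pyridin-4-yl, pentyl and phenyl on the amide-type nitrogen differ at all, and what group there would give a readable value.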